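Cyano to nitro on the anilide ring of compound 1

The compounds below may be only part of what the source reports. "The series", "measured", "known", "first", "only" and "open" are said of these compounds alone.

Measured compounds:
compound 1 `CC(CSc1cc(C(F)(F)F)cc(C(F)(F)F)c1)C(=O)Nc1ccc(C#N)cc1C(F)(F)F`: 4570 nM
compound 2 `CC(CSc1ccc(C(F)(F)F)cc1)C(=O)Nc1ccc([N+](=O)[O-])cc1C(F)(F)F`: 54300 nM

In a functional assay on LNCaP cells (Homo sapiens) for antiproliferative activity, read by MTT assay, with a stated time of 96 h (a lower number here means a stronger inhibitor, a higher number a weaker inhibitor), compound 1 gives 4570 nM and holds the lowest number of the two. Compound 2, which in this assay gives 54300 nM, sits beyond the scatter from it, but compound 2 differs from compound 1 in two places at once, so no single step can be read from this pair.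

Compound 3 `CC(CSc1cc(C(F)(F)F)cc(C(F)(F)F)c1)C(=O)Nc1ccc([N+](=O)[O-])cc1C(F)(F)F` is not yet measured. It differs from compound 1 by nitro in place of cyano on an aromatic carbon. Going by the values given here, no measured pair shows this change alone. The expectation for the step from compound 1 to compound 3 is a modest loss, a 1.8-fold higher number from compound 1 to compound 3 (0.24 log units; within the scatter), with a real chance that it stays within the scatter. Compound 3 is therefore estimated at 8000 nM, in the range 2500 nM to 25000 nM.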

Compound 3, half-maximal inhibitory concentration: 43700 nM
The estimate for compound 3 lay 5.5-fold (0.74 log units) below the measured number; measured number above the stated range.
By their numbers in this assay, from the lowest: compound 1; then compounds 3 and 2 (each within the scatter of the next).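

In this assay, going by these compounds alone, the exchange of cyano for nitro gives a 9.6-fold higher number from compound 1 to compound 3 (0.98 log units; beyond the scatter) and is the first reading of a change at this position alone, on an aromatic carbon para to a large group and meta to a trifluoromethyl group. The step lies beyond the scatter, so the two groups are not interchangeable here, and cyano is the better of the two on the core of compound 1. Nothing measured accounts for the size of this step.

Within the data shown here, whether the same exchange has a similar effect on the core of compound 2, with its single trifluoromethyl group on the other ring, remains open. Also open, going by these compounds, is how this position responds to an amine, a carboxylic acid or a bare hydrogen.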